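Swapping the Amide Arm: Furan in Place of Phenethyl

The source may report more compounds than this note shows. Statements on the series, on what has been measured and on what is new or still open speak of the compounds shown alone.

Compound 1, `CN(C(=O)c1ccccc1)c1ccc2[nH]c(-c3n[nH]c4ccccc34)cc2n1`: 10600 nM
Compound 2, `CN(C(=O)CCc1ccccc1)c1ccc2[nH]c(-c3n[nH]c4ccccc34)cc2n1`: 11200 nM
Compound 3, `CN(C(=O)c1ccc(F)cc1)c1ccc2[nH]c(-c3n[nH]c4ccccc34)cc2n1`: 9270 nM

All three compounds share one core and differ only in the group attached to the carbonyl of the amide. In a functional assay on HCT-116 cells (Homo sapiens) for antiproliferative activity, read by MTT assay, with a stated time of 72 h (a higher number here means a weaker inhibitor, a lower number a stronger inhibitor), compound 2 gives the highest of the three numbers, but the differences are small: the step of a 1.1-fold higher number from compound 1 to compound 2 (0.02 log units; within the scatter) and the step of a 1.2-fold lower number from compound 2 to compound 3 (0.08 log units; within the scatter) both lie within the scatter, as does a 1.1-fold lower number from compound 1 to compound 3 (0.06 log units; within the scatter). On the numbers shown, the three compounds cannot be told apart.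

Compound 4, `CN(C(=O)c1ccco1)c1ccc2[nH]c(-c3n[nH]c4ccccc34)cc2n1`, is not yet measured. It differs from compound 2 by furan-2-yl in place of phenethyl on a carbonyl carbon. For the measured compounds named here, every change at this same position so far, from phenyl to phenethyl and from phenethyl to 4-fluorophenyl, has left this assay unchanged beyond the scatter, so no step beyond the scatter is expected for the move to furan-2-yl either.

The expected step from compound 2 is a 1.1-fold lower number from compound 2 to compound 4 (0.03 log units; within the scatter). Compound 4 is therefore estimated at 10500 nM, within a range of 5000 nM to 22000 nM.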

Compound 4, half-maximal inhibitory concentration: 30000 nM
Estimate against measurement, compound 4: 2.9-fold (0.46 log units) below, and the stated range ends below it.
By their numbers in this assay, from the lowest: compounds 3, 1 and 2 (each within the scatter of the next); then compound 4.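

Placed on this carbonyl carbon, furan-2-yl is the first group here to move the number in this assay beyond the scatter, giving a 2.7-fold higher number from compound 2 to compound 4 (0.43 log units; beyond the scatter) and a 2.8-fold higher number from compound 1 to compound 4 (0.45 log units; beyond the scatter) and a 3.2-fold higher number from compound 3 to compound 4 (0.51 log units; beyond the scatter) as well. The position is therefore not indifferent to every aromatic group: phenyl, phenethyl and 4-fluorophenyl cannot be told apart, while compound 4, with its five-membered aromatic ring, is the weakest inhibitor of the four. Nothing available here explains why furan-2-yl stands apart from the other three groups.

The compounds shown leave open whether the ring oxygen or the five-membered ring itself goes with the weaker number. A thiophen-2-yl group, with sulfur in place of the oxygen, or a saturated tetrahydrofuran-2-yl group on the same carbonyl carbon would help separate the two.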